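Aryl substituent removal in a nitrophenyl amide series

A few compounds are considered here, and "the series" means these few. Any claim that something is new, unique, unknown or untested is made for them only; others in the source may bear on it.

Measured in a functional assay on the whole organism (strain albino) for inhibition, with Rattus norvegicus as the target, read by paw edema, with stated times of 1 h and 3 h, at a dose of 25 mg/kg by the oral route; a higher number here means more inhibition at the dose given (going by the name of the read-out), a lower number less inhibition:
compound 1 `CC1=C(C(=O)Nc2ccc(F)cc2)C(c2ccc([N+](=O)[O-])cc2)n2c(s/c(=C/c3ccc(Cl)cc3Cl)c2=O)=N1`, 17%
compound 2 `COc1ccc(/C=c2/sc3n(c2=O)C(c2ccc([N+](=O)[O-])cc2)C(C(=O)Nc2ccc(F)cc2)=C(C)N=3)cc1`, 12%
compound 3 `CC1=C(C(=O)Nc2ccc(F)cc2)C(c2ccc([N+](=O)[O-])cc2)n2c(s/c(=C/c3ccccc3Cl)c2=O)=N1`, 19%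

Compound 3 gives the highest of the three numbers, though each step to it is within the scatter: a number 2 percentage points higher from compound 1 to compound 3 (within the scatter) and a number 7 percentage points higher from compound 2 to compound 3 (within the scatter). Compound 4 `CC1=C(C(=O)Nc2ccc(F)cc2)C(c2ccc([N+](=O)[O-])cc2)n2c(s/c(=C/c3ccccc3)c2=O)=N1` differs from compound 3 in one place: hydrogen in place of chloro on an aromatic carbon. Among the measured compounds shown here, the closest precedent, also hydrogen in place of chloro on an aromatic carbon, is a number 2 percentage points higher from compound 1 to compound 3 (within the scatter), within the scatter; the aryl exchanges a number 5 percentage points lower from compound 1 to compound 2 (within the scatter) and a number 7 percentage points higher from compound 2 to compound 3 (within the scatter) likewise stayed within it. No step beyond the scatter is therefore expected in this assay. Compound 4 is estimated at 18%, between 8% and 28%. The expected step is a number 1 percentage points lower from compound 3 to compound 4 (within the scatter).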

Compound 4, a percentage reported as inhibition, in the whole organism at one dose (the size of the read-out at that dose, not a potency): 7%
The estimate for compound 4 lay 11 percentage points above the measured number; the measured number lies below the stated range.
By their numbers in this assay, from the lowest: compounds 4, 2, 1 and 3 (each within the scatter of the next, the first and the last beyond it).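

In this assay, among the compounds shown here, hydrogen in place of chloro ortho to a large group gives a number 12 percentage points lower from compound 3 to compound 4 (beyond the scatter), the only step here beyond the scatter, whereas the same exchange in a number 2 percentage points higher from compound 1 to compound 3 (within the scatter) stayed within it. The other two steps to phenyl, a number 5 percentage points lower from compound 2 to compound 4 (within the scatter) and a number 10 percentage points lower from compound 1 to compound 4 (within the scatter), do not separate these aryl groups, so the clear loss holds only for 2-chlorophenyl to phenyl. Nothing available explains this step.

From the compounds shown here alone, whether a bromo, methyl or amino group at that place would behave like chloro or like hydrogen remains open. Also open, going by these compounds, is whether the step recurs with other groups on the shared core.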